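This account rests on a few compounds, and the source may have more. Where it says the series, first, only, none or still open, it means among the compounds named here.

In an ADME assay on NIH3T3 cells (Mus musculus) for cytotoxicity, with a stated time of 72 h (a higher number here means a weaker inhibitor, a lower number a stronger inhibitor), compound 1 `OC[C@H]1O[C@@H](n2cnc3c(NCc4ccc(Br)cc4)ncnc32)[C@H](O)[C@@H]1O` gives > 166000 nM, which is a limit of the assay and not a number. For compound 2 `OC[C@H]1O[C@@H](n2cnc3c(NCc4c(F)ccc(F)c4F)ncnc32)[C@H](O)[C@@H]1O` the result is "not determined" (no result reported), so compound 2 has no place of its own on the numbers. Compound 3 `OC[C@H]1O[C@@H](n2cnc3c(NCc4ccc(F)cc4Cl)ncnc32)[C@H](O)[C@@H]1O` is still unmeasured. The structural change is 2-chloro-4-fluorophenyl in place of 2,3,6-trifluorophenyl on a saturated chain carbon bound to a nitrogen on an aromatic ring, with 2-chloro-4-fluorophenyl in place of 2,3,6-trifluorophenyl on a saturated chain carbon bound to a nitrogen on an aromatic ring. For the measured compounds named here, no measured step is available as a guide, and no shift beyond the scatter is expected in this assay. Compound 3 is expected at 170000 nM, with an estimated range of 60000 nM to 400000 nM.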

Compound 3, half-maximal inhibitory concentration: > 166000 nM
Compound 3 ended at the assay's limit (the forecaster's own chance of this, stated with the estimate: 70%); the middle value is on the limit's open side.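

Compound 3 gives > 166000 nM, a limit and not a number, so no new step can be read from it to compound 1 or compound 2. The compounds shown leave open whether any change of the phenyl group on the shared core moves the value at all.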